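This account rests on a few compounds, and the source may have more. Where it says the series, first, only, none or still open, it means among the compounds named here.

In a functional assay on DA-3 cells for cytotoxicity against DA-3 cell line (Mus musculus), read by MTT assay (on this read-out higher numbers stand for weaker inhibition and lower numbers for stronger inhibition), compound 2 `CC(=O)[C@@]1(C)C(=O)O[C@@H](OC(=O)C(C)(C)C)[C@H]1C` gives 1000 nM as the lowest number measured, while compound 1 `CC(=O)O[C@@H]1OC(=O)[C@](C)(C(C)=O)[C@@H]1C` gives 7000 nM as the next. Compound 3 `CCO[C@@H]1OC(=O)[C@](C)(C(C)=O)[C@@H]1C` reads > 50000 nM and this value is a limit of the assay. Compound 4 `CC(=O)[C@]1(C)C(=O)O[C@@H](OC(=O)C(C)(C)C)[C@H]1C` is still unmeasured and relates to compound 2 as follows: the two compounds have the same atoms and bonds and differ only in configuration as drawn: 1 of 3 stereo elements differ; a stereocentre at a saturated ring carbon is drawn S in compound 2 and R in compound 4. Three measured steps exist, namely a 7.0-fold lower number from compound 1 to compound 2 (0.85 log units; beyond the scatter) and an at least 7.1-fold higher number from compound 1 to compound 3 (0.85 log units; beyond the scatter) and the large at least 50-fold higher number from compound 2 to compound 3 (1.69 log units; beyond the scatter) but each alters the group on oxygen and none alters configuration, so they set no size for this change. Compound 4 keeps that group, and a modest rise in this assay is expected, with wide uncertainty, as a 2.0-fold higher number from compound 2 to compound 4 (0.30 log units; within the scatter) in this estimate. For compound 4 the estimated value is 2000 nM within a range from 500 nM to 10000 nM.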

Compound 4, half-maximal inhibitory concentration: 4000 nM
The estimate for compound 4 lay 2.0-fold (0.30 log units) below the measured number, and the stated range covers the measured number.
By their numbers in this assay, from the lowest: compound 2; then compounds 4 and 1 (each within the scatter of the next). At a limit, above all of these: compound 3.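

Inverting a single stereocentre at a saturated ring carbon, from S to R, brings a 4.0-fold higher number from compound 2 to compound 4 (0.60 log units; beyond the scatter) in this assay. Within the data shown here, the earlier steps all altered the group on oxygen, so this is the first sign that configuration at this carbon alone moves the read-out. The step can be assigned to that stereocentre with nothing else involved: the fact that compounds 2 and 4 differ only in the configuration as drawn

On these data alone, it stays open whether the same inversion moves the number equally with acetyl on the oxygen, as in compound 1, and what the other two stereo elements contribute. Also open, as far as these compounds go, is how a benzoyl group or a longer chain on that oxygen would read.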